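Thioether to methylamine linker in a pyrazolopyrimidinone series

A few compounds are considered here, and "the series" means these few. Any claim that something is new, unique, unknown or untested is made for them only; others in the source may bear on it.

Working notes on two measured analogues and one to be tested in an assay on isolated protein for inhibition of Retinaldehyde dehydrogenase 3 (Homo sapiens), tested at 20 uM; on this read-out higher numbers stand for more inhibition at the one concentration tested (going by the name of the read-out) and lower numbers for less inhibition. Compound 1 `Cn1ncc2c(=O)n(-c3ccccc3)c(NCc3cccc(F)c3)nc21` gives 58% in this assay. Compound 2 `Cn1ncc2c(=O)n(-c3ccccc3)c(CSc3cccc(F)c3)nc21` gives 86% in this assay, the higher of the two numbers recorded, and its nearest neighbour, compound 1, sits beyond the usual scatter below it. No step between compounds that differ in a single place has been recorded, so the two values stand on their own and carry no cause.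

Compound 3 `CN(Cc1nc2c(cnn2C)c(=O)n1-c1ccccc1)c1cccc(F)c1` is the next analogue for this assay. It differs from compound 2 as follows: a group of 9 heavy atoms (7 carbon, 1 nitrogen, 1 fluorine; one six-membered aromatic ring of carbon only) in place of a group of 8 heavy atoms (6 carbon, 1 fluorine, 1 sulfur; one six-membered aromatic ring of carbon only), on a saturated chain carbon bound to an aromatic carbon. Going from the number for compound 2, a step downward of moderate size is expected for compound 3, possibly not beyond the scatter, as the estimate a number 16 percentage points lower from compound 2 to compound 3 (beyond the scatter) means. Compound 3 is thus estimated at 70% in this assay, with a range from 45% to 90%.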

Compound 3, a percentage reported as inhibition, at one concentration (the size of the read-out at that concentration, not a potency): 74%
Compound 3: the middle estimate sits 4 percentage points below what was measured; the range from low to high includes it.
By their numbers in this assay, from the lowest: compound 1; then compound 3; then compound 2.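

For the compounds shown here, the first single-place step is now on record: in this assay, exchanging the (3-fluorophenyl)sulfanyl group on a saturated chain carbon bound to an aromatic carbon for the nitrogen-containing group of compound 3 gives a number 12 percentage points lower from compound 2 to compound 3 (beyond the scatter). This position therefore responds to the change, yet compound 3 still gives 74%, so substantial inhibition at the one concentration tested does not depend on the sulfur in this pair. No measurement bears on why the number falls.

Going by these compounds, it remains open how an ether oxygen in place of the sulfur, or a longer chain carrying the fluorinated ring, would read at this position. Going by these compounds alone, also open is whether the step holds with chlorine in place of fluorine, and a single-concentration read-out gives no potency for either compound.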